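This account rests on a few compounds, and the source may have more. Where it says the series, first, only, none or still open, it means among the compounds named here.

Measured compounds:
compound 1 `C/C(=N\OC(=O)Nc1ccccc1)c1cccc(-c2ccccc2)c1` — 69 nM
compound 2 `COc1ccc(NC(=O)O/N=C(\C)c2cccc(-c3ccccc3)c2)cc1` — 28 nM
compound 3 `C/C(=N\OC(=O)Nc1ccc2sccc2c1)c1cccc(-c2ccccc2)c1` — 232 nM

In an assay for inhibition of Fatty-acid amide hydrolase 1 (Mus musculus), read by scintillation counting (a lower number here means a stronger inhibitor, a higher number a weaker inhibitor), compound 1 stands second highest of the three numbers. The step of a 2.5-fold lower number from compound 1 to compound 2 (0.39 log units; beyond the scatter) and the step of a 3.4-fold higher number from compound 1 to compound 3 (0.53 log units; beyond the scatter) both alter the ring on the amide-type nitrogen, and the step of an 8.3-fold higher number from compound 2 to compound 3 (0.92 log units; beyond the scatter) does the same. Compound 4 `C/C(=N\OC(=O)Nc1ccccc1)c1cccc(-c2cccc(C(N)=O)c2)c1` differs from compound 1 elsewhere: carbamoyl in place of hydrogen on an aromatic carbon. No measured step touches that outer ring, so none of the three steps bears directly on this change; the shown data leave it untested. He therefore expects no step beyond the scatter, a 1.2-fold higher number from compound 1 to compound 4 (0.06 log units; within the scatter), in this assay. His estimate for compound 4 is 80 nM, with a range from 25 nM to 260 nM.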

Compound 4, half-maximal inhibitory concentration: 84 nM
Compound 4: middle estimate off by 1.1-fold (0.02 log units), on the low side; the measured number falls inside the stated range.
By their numbers in this assay, from the lowest: compound 2; then compounds 1 and 4 (each within the scatter of the next); then compound 3.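

Moving the change to the outer ring, phenyl to 3-carbamoylphenyl gives a 1.2-fold higher number from compound 1 to compound 4 (0.09 log units; within the scatter) in this assay, so this position carries carbamoyl with no step beyond the scatter. Each change on the amide-type nitrogen gave a step beyond the scatter, so the outer ring reads differently for this one substituent. No supporting evidence on this result is available.

The compounds shown leave open how a carboxylic acid or an amine at this place would read. They also leave open whether carbamoyl would read the same when paired with 4-methoxyphenyl on the amide-type nitrogen.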